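Swapping Iodophenyl for Naphthalenyl on a Second Core

The source may report more compounds than this note shows. Statements on the series, on what has been measured and on what is new or still open speak of the compounds shown alone.

Compound 1 `CN(c1ccc(NC(=O)c2ccc(I)cc2)cc1OCc1cc(Cl)ccc1Cl)S(C)(=O)=O` gives 660 nM in a functional assay on SK-BR-3 cells (Homo sapiens) for antiproliferative activity, read by MTT assay, with a stated time of 48 h; on this read-out lower numbers stand for stronger inhibition and higher numbers for weaker inhibition.
Compound 2 `CN(c1ccc(NC(=O)c2ccc3ccccc3c2)cc1OCc1cc(Cl)ccc1Cl)S(C)(=O)=O` gives 2210 nM in this assay.
Compound 3 `COc1ccc(OC)c(COc2cc(NC(=O)c3ccc(I)cc3)ccc2NS(C)(=O)=O)c1` gives 11.8 nM in this assay.

Compound 2 differs from compound 1 in one place: naphthalen-2-yl in place of 4-iodophenyl on a carbonyl carbon This change brought a 3.3-fold higher number from compound 1 to compound 2 (0.52 log units; beyond the scatter). Compound 4 `COc1ccc(OC)c(COc2cc(NC(=O)c3ccc4ccccc4c3)ccc2NS(C)(=O)=O)c1` carries the same change on the core of compound 3: naphthalen-2-yl in place of 4-iodophenyl on a carbonyl carbon The two cores differ in more than one place, and that difference is not broken down here. Compound 3 stands clearly lowest of the three measured numbers, so its core is the more potent starting point. Among the compounds with values here, only one measured example of this change exists, and it is a 3.3-fold higher number from compound 1 to compound 2 (0.52 log units; beyond the scatter). Resting on that single example, the expected step is a 3.4-fold higher number from compound 3 to compound 4 (0.53 log units; beyond the scatter), a weakening of similar size. Compound 4 is thus estimated at 40 nM, with a likely range from 15 nM to 120 nM.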

Compound 4, half-maximal inhibitory concentration: 13.3 nM
Beside the measured number, compound 4's estimate is 3.0-fold (0.48 log units) above it, and the stated range ends above it.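

The same swap on the second core gives a 1.1-fold higher number from compound 3 to compound 4 (0.05 log units; within the scatter) in this assay and so leaves potency essentially unchanged, whereas it clearly weakened the core of compound 1. The size of this step therefore did not carry over from one core to the other: the same change on two cores in this assay, a 3.3-fold higher number (0.52 log units; beyond the scatter) from compound 1 to compound 2 and a 1.1-fold higher number (0.05 log units; within the scatter) from compound 3 to compound 4, 3.0-fold (0.47 log units) apart, beyond the scatter of two such steps

Within the data shown here, with only one pair on each core, this shows that the step can depend on the core, but not which of the differences between the two cores is responsible.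

The only groups shown on the carbonyl carbon are 4-iodophenyl and naphthalen-2-yl. Going by these compounds, it remains open how the two cores would respond to a phenyl ring bearing an amine or a carboxylic acid at that place.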